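The source may report more compounds than this note shows. Statements on the series, on what has been measured and on what is new or still open speak of the compounds shown alone.

Compound 1 `CC(C)CCOc1ccc2oc(/C=C/[S+](C)[O-])cc(=O)c2c1` and compound 2 `CCCOc1ccc2oc(/C=C/[S+](C)[O-])cc(=O)c2c1` share one core and differ only in the chain on the oxygen. Going by the values given here, in a functional assay on DLD-1 cells (Homo sapiens) for cytotoxicity, with a stated time of 48 h (a lower number here means a stronger inhibitor, a higher number a weaker inhibitor), compound 1 gives 4100 nM and compound 2 gives 6200 nM, so the two numbers lie within the usual scatter of each other and compound 2 has no clear place above or below its only neighbour. Compound 3 `COc1ccc2oc(/C=C/[S+](C)[O-])cc(=O)c2c1` takes the chain down further. Its change from compound 2 is hydrogen in place of ethyl on a saturated chain carbon bound to an oxygen on an aromatic ring, or propoxy to methoxy. Among the compounds with values here, only one measured step bears on this, namely a 1.5-fold higher number from compound 1 to compound 2 (0.18 log units; within the scatter), where methyl replaces isopropyl on a saturated chain carbon. That single step is small, so no step beyond the scatter is expected in this assay, although a slight drift towards a higher number would not be surprising. The estimated step is a 1.2-fold higher number from compound 2 to compound 3 (0.08 log units; within the scatter). For compound 3 the expected value is 7500 nM, with an estimated range from 3000 nM to 19000 nM.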

Compound 3, half-maximal inhibitory concentration: 5700 nM
Compound 3: the middle estimate sits 1.3-fold (0.12 log units) above what was measured, and the stated range covers the measured number.
By their numbers in this assay, from the lowest: compounds 1, 3 and 2 (each within the scatter of the next).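

Going from propoxy to methoxy gives a 1.1-fold lower number from compound 2 to compound 3 (0.04 log units; within the scatter), and hydrogen in place of isobutyl on the same saturated chain carbon gives a 1.4-fold higher number from compound 1 to compound 3 (0.14 log units; within the scatter), both in this assay. The earlier pair changed only the far end of the chain, whereas compound 3 cuts it back to methyl, and even this largest cut among the three leaves all the numbers within the scatter of one another, so for these three compounds the chain on this oxygen can shrink to methyl with no clear shift in the number and no order among them. Nothing was measured on these compounds beyond the cell numbers themselves.

From the compounds shown here alone, all three compounds carry only plain saturated chains at this place, so it remains open whether an amine, a carboxylic acid, a benzyl group or a longer chain on the oxygen would move the number beyond the scatter. Also open, going by these compounds, is whether this flat picture holds in cells other than the ones tested in this assay, or when another part of the shared core changes.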